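Fluoro for methoxy in the weak 3-methoxyphenyl compound

The source may hold more compounds than are shown below. What is called first, only, known or untested is meant among the compounds shown, and "the series" means these compounds.

Values from a functional assay on HeLa cells (Homo sapiens) for antiproliferative activity, read by MTT assay, with a stated time of 72 h (on this read-out higher numbers stand for weaker inhibition and lower numbers for stronger inhibition), follow
- compound 1 `COc1cccc(-c2ncnn2-c2cc(OC)c(OC)c(OC)c2)c1` gives > 10000 nM
- compound 2 `CCOc1ccc(-c2ncnn2-c2cc(OC)c(OC)c(OC)c2)cc1` gives 15 nM

Compound 1 has the reading > 10000 nM, which is a limit of the assay and not a number. For the measured compounds named here, compound 2 gives a true number of 15 nM and is the only measured compound that does. Going by the values given here, the series so far offers no measured step with a single change, so no direct guide to the size of a substitution effect exists.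

Compound 3 `COc1cc(-n2ncnc2-c2cccc(F)c2)cc(OC)c1OC` carries one change from compound 1 fluoro in place of methoxy on an aromatic carbon with the 3-methoxyphenyl becoming 3-fluorophenyl, fluoro in place of methoxy on an aromatic carbon, meta to a large group. In this assay only a modest move toward stronger inhibition is expected, and a reading again at the limit is quite possible. The estimated at least 1.6-fold lower number from compound 1 to compound 3 (0.22 log units; that floor lies within the scatter) is expected to remain small next to the gap between the two measured values. The expected value for compound 3 is 6000 nM with a range from 800 nM to 10000 nM expected to cover four readings in five.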

Compound 3, half-maximal inhibitory concentration: > 10000 nM
Compound 3: a limit, no number (the forecaster's own chance of this, stated with the estimate: 60%); at least 1.6-fold (0.22 log units) between middle value and limit.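

No step can be read from compound 1 to compound 3, because both readings in this assay are limits and not numbers: the limit of > 10000 nM in this assay, at which 2 of the 3 values shown sit.

The compounds shown leave open how far compound 1 and compound 3 each lie from that limit, and so whether fluoro in place of methoxy changes inhibition at all.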